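Side-chain exchange on the shared core: compound 2 to compound 3

The source may report more compounds than this note shows. Statements on the series, on what has been measured and on what is new or still open speak of the compounds shown alone.

Measured compounds:
compound 1 `CC[C@H](C)[C@H](NC(=O)CN(c1nc(Cl)nc2[nH]cnc12)C1CC1)C(=O)O` — 30.3%
compound 2 `NC(=O)C[C@H](NC(=O)CN(c1nc(Cl)nc2[nH]cnc12)C1CC1)C(=O)O` — 29.7%

In a functional assay on the whole organism (Tail, strain ICR) with Mus musculus as the target, in the tail flick test, with a stated time of 30 min, at a dose of 25 umol/kg by the oral route (on this read-out higher numbers stand for a stronger effect at the one dose given and lower numbers for a weaker effect), compound 1 gives 30.3% and compound 2 gives 29.7%. Going by the values given here, compound 2 sits alongside compound 1, the only other number, within the scatter of it. Compound 3 `C[C@@H](O)[C@H](NC(=O)CN(c1nc(Cl)nc2[nH]cnc12)C1CC1)C(=O)O` differs from compound 2 in one place: 1-hydroxyethyl in place of carbamoylmethyl on a saturated chain carbon bound to an amide-type nitrogen and a carbonyl carbon. Among the compounds with values here, the single measured step at this place, a number 0.6 percentage points lower from compound 1 to compound 2 (within the scatter), was within the scatter, so nothing seen so far points to a shift in this assay. The step expected is a number 0.3 percentage points higher from compound 2 to compound 3 (within the scatter), none beyond the scatter. Compound 3 is therefore estimated at 30%, with a range from 15% to 45%.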

Compound 3, a percentage reported as activity, at one dose (the size of the read-out at that dose, not a potency): 18.6%
Compound 3: middle estimate off by 11.4 percentage points, on the high side, within the range that was stated.
By their numbers in this assay, from the lowest: compound 3; then compounds 2 and 1 (each within the scatter of the next).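

In this assay, 1-hydroxyethyl in place of carbamoylmethyl gives a number 11.1 percentage points lower from compound 2 to compound 3 (beyond the scatter), and hydroxy in place of ethyl gives a number 11.7 percentage points lower from compound 1 to compound 3 (beyond the scatter). The position, which showed no difference between sec-butyl and carbamoylmethyl, therefore does respond to the side chain, with 1-hydroxyethyl alone standing apart from both. Nothing available explains this drop.

On these data alone, whether it follows from the hydroxy group or from the configuration of 1-hydroxyethyl stays open. So does the outcome with an amine or a carboxylic acid on a side chain at this place.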